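The source may hold more compounds than are shown below. What is called first, only, known or untested is meant among the compounds shown, and "the series" means these compounds.

The measured compounds and their results in a functional assay on MV4-11 cells (Homo sapiens) for inhibition, read by resazurin assay, with a stated time of 72 h; a lower number here means a stronger inhibitor of growth, a higher number a weaker inhibitor of growth:

compound 1, `COc1ccc(Nc2nccc(-c3sc(SC)nc3C)n2)c(OC)c1`, gives 530 nM
compound 2, `CCCSc1nc(C)c(-c2ccnc(Nc3ccc(OC)cc3OC)n2)s1`, gives 2240 nM
compound 3, `CCCCOc1nc(C)c(-c2ccnc(Nc3ccc(OC)cc3OC)n2)s1`, gives 7860 nM

Compound 1 and compound 2 differ in one place only, by hydrogen in place of ethyl on a saturated chain carbon bound to a sulfur. That change gave a 4.2-fold lower number from compound 2 to compound 1 (0.63 log units; beyond the scatter). Compound 2 and compound 3 have different cores, the difference being (butoxy in place of propylsulfanyl on an aromatic carbon), and it gave a 3.5-fold higher number from compound 2 to compound 3 (0.55 log units; beyond the scatter). Between the two that stand furthest apart, a 15-fold higher number from compound 1 to compound 3 (1.17 log units; beyond the scatter). Compound 3 therefore has the highest number of the three.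

Compound 4, `CCOc1nc(C)c(-c2ccnc(Nc3ccc(OC)cc3OC)n2)s1`, has not yet been measured. It differs from compound 3 by hydrogen in place of ethyl on a saturated chain carbon, two bonds along the chain from an oxygen on an aromatic ring. Among the compounds with values here, this is the same kind of change as the one from compound 2 to compound 1, but not the same: there the place was on a saturated chain carbon bound to a sulfur, here it is on a saturated chain carbon, two bonds along the chain from an oxygen on an aromatic ring, and the two changes sit on different cores. Within the data shown here, only that one earlier example is available to lean on.

For compound 4 the expected step is a 3.1-fold lower number from compound 3 to compound 4 (0.50 log units; beyond the scatter), set a little smaller than a 4.2-fold lower number from compound 2 to compound 1 (0.63 log units; beyond the scatter), as the earlier step came from a different core and place. Compound 4 is thus estimated to give about 2500 nM in this assay, most likely between 900 nM and 7000 nM.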

Compound 4, concentration for 50% growth inhibition: 3890 nM
For compound 4 the middle estimate is 1.6-fold (0.19 log units) below the measured one; the measured number falls inside the stated range.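

Shortening butoxy to ethoxy gave a 2.0-fold lower number from compound 3 to compound 4 (0.31 log units; beyond the scatter) in this assay, the same direction as shortening propylsulfanyl to methylsulfanyl, and the sizes of the two steps cannot be told apart: the same change on two cores in this assay, a 4.2-fold lower number (0.63 log units; beyond the scatter) from compound 2 to compound 1 and a 2.0-fold lower number (0.31 log units; beyond the scatter) from compound 3 to compound 4, 2.1-fold (0.32 log units) apart, within the scatter of two such steps. Exchanging the chain itself gives a mixed picture: ethoxy in place of propylsulfanyl gave a 1.7-fold higher number from compound 2 to compound 4 (0.24 log units; within the scatter), so those two compounds cannot be ranked, while ethoxy in place of methylsulfanyl gave a 7.3-fold higher number from compound 1 to compound 4 (0.87 log units; beyond the scatter), leaving compound 1 with the lowest number of the four. Two pairs suggest that removing ethyl from the end of these chains can carry from one core to the other, but they do not establish a general rule, and they cannot say how this change would behave with other chain lengths or on any other core.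

The compounds shown leave open whether methoxy would extend the step seen from butoxy to ethoxy, and whether ethylsulfanyl or a longer chain on the sulfur would fall in line with the two sulfur compounds. They also leave open what an amine or a carboxylic acid at the end of the chain would do to growth inhibition in these cells.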